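Trimming the sulfonamide: from compound 1 to compound 4

The source may hold more compounds than are shown below. What is called first, only, known or untested is meant among the compounds shown, and "the series" means these compounds.

Measured compounds:
compound 1, `CCC1C(=O)N(C)c2cnc(Nc3ccc(S(=O)(=O)NCC(C)C)cc3)nc2N1c1ccn(C)n1` — 31600 nM
compound 2, `CCC1C(=O)N(C)c2cnc(-n3ccc4cc(C(=O)NC(C)C)ccc43)nc2N1c1ccn(C)n1` — 22000 nM
compound 3, `CC[C@@H]1C(=O)N(C)c2cnc(-n3ccc4cc(C(=O)NC5CCCC5)ccc43)nc2N1C1CCCC1` — 670 nM

In a functional assay on A549 cells (Homo sapiens) for antiproliferative activity, read by CCK-8 assay, with a stated time of 72 h (on this read-out higher numbers stand for weaker inhibition of growth and lower numbers for stronger inhibition of growth), compound 1 gives 31600 nM, the highest of the three numbers shown. Compound 2 sits within the usual scatter of that result, so the two cannot be told apart. Compound 3, with 670 nM, lies well beyond the scatter, showing clearly stronger growth inhibition than compound 1; it differs from compound 1 in several places at once, so no single cause can be read from it.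

Compound 4, `CCC1C(=O)N(C)c2cnc(Nc3ccc(S(N)(=O)=O)cc3)nc2N1c1ccn(C)n1`, differs from compound 1 in one place: hydrogen in place of isobutyl on a sulfonamide nitrogen. Going by the values given here, no measured pair shows this change, so its effect is uncertain. Given that compound 1 itself is weak at 31600 nM, compound 4 is expected to stay in the same weak region, with a step of a 1.3-fold higher number from compound 1 to compound 4 (0.10 log units; within the scatter) that may not exceed the scatter in this assay. The estimate for compound 4 is 40000 nM, within a range from 12000 nM to 130000 nM.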

Compound 4, concentration for 50% growth inhibition: "not active" (no number reported)
Compound 4: no number reported; no gap can be computed for the estimate.
By their numbers in this assay, from the lowest: compound 3; then compounds 2 and 1 (each within the scatter of the next).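

Compound 4 is reported as "not active" with no number, so no step can be read between compound 1 and compound 4. The compounds shown leave open how far hydrogen in place of isobutyl on the sulfonamide nitrogen shifts growth inhibition, and no available evidence bears on this result.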